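Quinolin-6-yl for 2,3-dimethylphenyl: compound 4 from compound 1

The compounds below may be only part of what the source reports. "The series", "measured", "known", "first", "only" and "open" are said of these compounds alone.

Compound 1 `CCOC(=O)C(Sc1nc(Cl)cc(Nc2cccc(C)c2C)n1)c1ccccc1` is tested in an assay for inhibition of Polyunsaturated fatty acid 5-lipoxygenase (Homo sapiens) (on this read-out higher numbers stand for weaker inhibition and lower numbers for stronger inhibition), and gives 1800 nM. Among the three measured members of the series it holds the second highest number. Compound 2 `CCCCCCC(Sc1nc(Cl)cc(Oc2ccc3ncccc3c2)n1)C(=O)OCC` gives 1700 nM, a number within the scatter of that of compound 1, so no order between the two can be read. Compound 3 `O=C(O)CSc1nc(Cl)cc(Nc2cccc3c2CCC3)n1` gives 3900 nM, a higher number than compound 1 and beyond the scatter. For the measured compounds named here, no pair of measured compounds differs in a single place, so no step size is known from measurement.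

Compound 4 `CCOC(=O)C(Sc1nc(Cl)cc(Nc2ccc3ncccc3c2)n1)c1ccccc1` differs from compound 1 in one place: quinolin-6-yl in place of 2,3-dimethylphenyl on a nitrogen on an aromatic ring. The quinolin-6-yl group appears elsewhere in the series, on an oxygen in compound 2, whose value 1700 nM sits within the scatter of compound 1. That hint rests on a different linking atom and a different side chain and is weak. The expectation is a step of a 1.1-fold higher number from compound 1 to compound 4 (0.05 log units; within the scatter) with no clear direction beyond the scatter. Compound 4 is therefore estimated at 2000 nM, with a range from 700 nM to 6000 nM.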

Compound 4, half-maximal inhibitory concentration: 1200 nM
The estimate for compound 4 lay 1.7-fold (0.22 log units) above the measured number; measured number inside the range.
By their numbers in this assay, from the lowest: compounds 4, 2 and 1 (each within the scatter of the next); then compound 3.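

In this assay, for the compounds shown here, quinolin-6-yl in place of 2,3-dimethylphenyl on a nitrogen on an aromatic ring gives a 1.5-fold lower number from compound 1 to compound 4 (0.18 log units; within the scatter), the first step measured at a single place. The two numbers lie within the scatter, so no order between compound 1 and compound 4 can be read, and this place holds the larger quinolin-6-yl group, with its ring nitrogen and hydrogen-bond acceptor, without a step beyond the scatter. No measurement at hand bears on the reason for this result.

A naphthalen-2-yl group on the same nitrogen would test whether the ring nitrogen of quinolin-6-yl matters at this place. On these data alone, how a primary amide in place of the ethyl ester of compound 4 would read also remains open.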